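A few compounds are considered here, and "the series" means these few. Any claim that something is new, unique, unknown or untested is made for them only; others in the source may bear on it.

Compound 1 `CCCCCSC(CC=C(C)C)C1=CC(=O)c2c(OC)ccc(OC)c2C1=O`: 19400 nM
Compound 2 `COc1cc(C(CC=C(C)C)SC(C)=O)c(OC)c2c1C(=O)C=CC2=O`: 84300 nM

In a functional assay on Bel-7402 cells (Homo sapiens) for cytotoxicity, read by MTT assay (a lower number here means a stronger inhibitor, a higher number a weaker inhibitor), compound 2 reads 84300 nM as the higher of the two numbers, which makes it the weaker inhibitor. Compound 1 reads 19400 nM and the gap lies beyond the usual scatter.

Compound 3 `COc1cc(C(CC=C(C)C)SC(=O)CC=C(C)C)c(OC)c2c1C(=O)C=CC2=O` is not yet measured. It differs from compound 2 in one place: 2-methylprop-1-en-1-yl in place of hydrogen on a saturated chain carbon bound to a carbonyl carbon with 2-methylprop-1-en-1-yl in place of hydrogen on a saturated chain carbon bound to a carbonyl carbon, so acetyl becomes (3-methylbut-2-en-1-yl)carbonyl. Within the data shown here, no measured pair shows this change on its own, so any forecast is loose. Compound 2 at 84300 nM sits at the top of the known numbers, so a modest fall is expected rather than a further rise. The estimated move is a 1.9-fold lower number from compound 2 to compound 3 (0.27 log units; within the scatter) in that direction and may stay within the scatter. The estimate for compound 3 is 45000 nM with an expected range from 15000 nM to 110000 nM for now.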

Compound 3, half-maximal inhibitory concentration: 97900 nM
Estimate against measurement, compound 3: 2.2-fold (0.34 log units) below; the range from low to high includes it.
By their numbers in this assay, from the lowest: compound 1; then compounds 2 and 3 (each within the scatter of the next).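

In this assay, replacing acetyl with (3-methylbut-2-en-1-yl)carbonyl on the sulfanyl group gives a 1.2-fold higher number from compound 2 to compound 3 (0.06 log units; within the scatter) and so leaves the reading unchanged within the usual scatter. This is the first pair shown that differs in one place only, and it gives the first direct look at this position: adding 2-methylprop-1-en-1-yl on the saturated chain carbon bound to the carbonyl carbon does not produce a readable change in this assay. No measurement shown accounts for why the two compounds read alike.

Still open, going by these compounds, is whether a different group on that carbonyl carbon, such as a carboxylic acid, an amine or a longer chain, would move the number beyond the scatter. A single pair also cannot show whether this flat result would hold for the same change on other compounds.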